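The source may hold more compounds than are shown below. What is called first, only, known or untested is meant among the compounds shown, and "the series" means these compounds.

Working notes on the series. In a functional assay on MDA-MB-231 cells (Homo sapiens) for antiproliferative activity, read by MTT assay, with a stated time of 72 h (a higher number here means a weaker inhibitor, a lower number a stronger inhibitor), compound 1 `CC1=CC[C@H]2[C@@H]1CC=C(C)[C@@H](CC[C@H]1[C@]3(C)CC[C@H](O)C(C)(C)O[C@H]3CC[C@@]1(C)O)C2(C)C` gives > 50000 nM, which is a limit of the assay and not a number. Compound 2 `CC1=CC[C@H]2[C@@H]1CC=C(C)[C@@H](CC[C@H]1[C@]3(C)CC[C@H](OC(=O)CCC(=O)O)C(C)(C)O[C@H]3CC[C@@]1(C)O)C2(C)C`, bearing (2-carboxyethyl)carbonyl on the oxygen, gives 29600 nM, and compound 3 `CC1=CC[C@H]2[C@@H]1CC=C(C)[C@@H](CC[C@H]1[C@]3(C)CC[C@H](OC(=O)c4ccccc4)C(C)(C)O[C@H]3CC[C@@]1(C)O)C2(C)C`, bearing benzoyl there, gives 18400 nM. For the measured compounds named here, compound 3 thus stands level with compound 2, as a 1.6-fold lower number from compound 2 to compound 3 (0.21 log units; within the scatter) shows, and these are the only two numbers so far. Against the limit, the two acylations give an at least 1.6-fold lower number from compound 1 to compound 2 (0.22 log units; that floor lies within the scatter) and an at least 2.7-fold lower number from compound 1 to compound 3 (0.43 log units; beyond the scatter).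

Compound 4 `CC1=CC[C@H]2[C@@H]1CC=C(C)[C@@H](CC[C@H]1[C@]3(C)CC[C@H](OC(=O)c4ccc(Cl)cc4)C(C)(C)O[C@H]3CC[C@@]1(C)O)C2(C)C` carries chloro in place of hydrogen on an aromatic carbon, para to a large group, so that benzoyl becomes (4-chlorophenyl)carbonyl. Going by the values given here, no measured step changes a substituent on the aromatic ring. The closest guide is the exchange of 2-carboxyethyl for phenyl in compound 3, which stayed within the scatter, so only a small shift is expected, with no firm direction. For the step, the expectation is a 1.2-fold lower number from compound 3 to compound 4 (0.09 log units; within the scatter). Compound 4 is expected at 15000 nM, with an estimated range of 6000 nM to 38000 nM.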

Compound 4, half-maximal inhibitory concentration: 12700 nM
Compound 4: the middle estimate sits 1.2-fold (0.07 log units) above what was measured, within the range that was stated.
By their numbers in this assay, from the lowest: compounds 4, 3 and 2 (each within the scatter of the next, the first and the last beyond it). At a limit, above all of these: compound 1.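

For the compounds shown here, the chloro in place of hydrogen on the aromatic ring is the first change on the ring itself, and by itself it stays inside the scatter, as a 1.4-fold lower number from compound 3 to compound 4 (0.16 log units; within the scatter) shows. Set against the 2-carboxyethyl ester, the (4-chlorophenyl)carbonyl ester clears the scatter with a 2.3-fold lower number from compound 2 to compound 4 (0.37 log units; beyond the scatter), a separation that the unsubstituted benzoyl ester did not reach. Compound 1 stands at a limit of the assay and not at a number, and the step to the (4-chlorophenyl)carbonyl ester reads only as a floor, an at least 3.9-fold lower number from compound 1 to compound 4 (0.59 log units; beyond the scatter), resting on this: the limit of > 50000 nM in this assay, at which 1 of the 4 values shown sits.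

Open, as far as these compounds go, is whether a ring substituent other than chloro, such as methoxy or an amine, would move the number beyond the scatter relative to compound 3. Also open, from the compounds shown here alone, is how a longer chain between the carbonyl and the aromatic ring would read.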